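This account rests on a few compounds, and the source may have more. Where it says the series, first, only, none or still open, it means among the compounds named here.

Measured in a functional assay on A549 cells (Homo sapiens) for antiproliferative activity, read by MTT assay, with a stated time of 72 h; a lower number here means a stronger inhibitor, a higher number a weaker inhibitor:
- compound 1 `CCCCCCCCNC[C@@H]1OC[C@H](N)[C@@H]1O`: > 128000 nM
- compound 2 `CCCCCCCCCCCNC[C@@H]1OC[C@H](N)[C@H]1O`: 9650 nM
- compound 3 `CCCCCCCCNC[C@@H]1OC[C@H](N)[C@H]1O`: 71800 nM

Compound 1 has only a limit in this assay, > 128000 nM, and not a number. Within the data shown here, its one measured neighbour differs only in the configuration as drawn, and that comparison gives an at least 1.7-fold lower number from compound 1 to compound 3 (0.25 log units; that floor lies within the scatter). This floor says little about the true size of the step.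

Compound 4 `CCCCCCCCCNC[C@@H]1OC[C@H](N)[C@@H]1O` keeps the configuration of compound 1 and changes the chain: methyl in place of hydrogen on a saturated chain carbon, eight bonds along the chain from an amine nitrogen. Among the measured compounds shown here, the only measured change of chain length is a 7.4-fold higher number from compound 2 to compound 3 (0.87 log units; beyond the scatter), where hydrogen replaces propyl at that same place. Read in reverse, that single pair links the longer chain to the lower number, but it was measured in the other configuration, and no pair in the configuration of compound 1 exists.

Compound 4 gains only a methyl, so a modest part of that step is the reasonable expectation. The expected result in this assay is an at least 1.2-fold lower number from compound 1 to compound 4 (0.10 log units; that floor lies within the scatter), a small move towards a lower number that may not clear the scatter. A reading that again gives only a limit would be no surprise.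

Compound 4 is estimated at 100000 nM, with an expected range of 45000 nM to 200000 nM.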

Compound 4, half-maximal inhibitory concentration: 22100 nM
For compound 4 the middle estimate is 4.5-fold (0.66 log units) above the measured one, and the stated range ends above it.
By their numbers in this assay, from the lowest: compound 2; then compound 4; then compound 3. At a limit, above all of these: compound 1.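

In this assay, methyl in place of hydrogen on a saturated chain carbon, eight bonds along the chain from an amine nitrogen, gives an at least 5.7-fold lower number from compound 1 to compound 4 (0.76 log units; beyond the scatter), so a single methyl at this place is already enough to move the number beyond the scatter. Among these compounds, this is the first pair in the configuration of compound 1, and it runs the same way as the only earlier chain pair, drawn in the other configuration, where the shorter chain gave a 7.4-fold higher number from compound 2 to compound 3 (0.87 log units; beyond the scatter). The true size of the new step cannot be given, because its starting point is a limit and not a number: the limit of > 128000 nM in this assay, at which 1 of the 4 values shown sits.

From the compounds shown here alone, how much the configuration alone matters stays open, since an at least 1.7-fold lower number from compound 1 to compound 3 (0.25 log units; that floor lies within the scatter) rests on that same limit and gives only a floor. Going by these compounds, how a longer chain or a phenyl group at this place would read in the configuration of compound 1 also remains open.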